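From Phenoxy to Benzyl on the Amine Side Chain

The source may report more compounds than this note shows. Statements on the series, on what has been measured and on what is new or still open speak of the compounds shown alone.

Of the compounds shown here, two that share one core have so far been measured in a functional assay on MDA-MB-231 cells (Homo sapiens) for inhibition; a lower number here means a stronger inhibitor, a higher number a weaker inhibitor. Compound 1 `O=C(NO)c1ccc(-c2ccc(CNCCOc3ccccc3)cn2)s1` gives 300 nM and holds the lowest number of the two. Compound 2 `O=C(NO)c1ccc(-c2ccc(CNc3ccccc3)cn2)s1` gives 630 nM in this assay, a higher number that lies beyond the usual scatter, so compound 1 is the stronger inhibitor of the pair.

Compound 3 `O=C(NO)c1ccc(-c2ccc(CNCCCc3ccccc3)cn2)s1` has not yet been tested. It differs from compound 1 in one place: benzyl in place of phenoxy on a saturated chain carbon, two bonds along the chain from an amine nitrogen. The core, the amine and the rest of the chain are unchanged. Within the data shown here, no measured pair shows this particular exchange, so the expectation rests on the modest size of the change, in which one group of seven heavy atoms gives way to another. The step of a 1.2-fold higher number from compound 1 to compound 3 (0.07 log units; within the scatter) is expected to be small, quite possibly within the scatter, and in either direction. For compound 3 in this assay the estimate is 350 nM, with a range from 150 nM to 800 nM.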

Compound 3, half-maximal inhibitory concentration: 250 nM
The estimate for compound 3 lay 1.4-fold (0.15 log units) above the measured number; low and high end bracket the measured number.
By their numbers in this assay, from the lowest: compounds 3 and 1 (each within the scatter of the next); then compound 2.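

In this assay, benzyl in place of phenoxy on a saturated chain carbon, two bonds along the chain from an amine nitrogen, gives a 1.2-fold lower number from compound 1 to compound 3 (0.08 log units; within the scatter), so the two groups cannot be told apart here. Among these compounds, this is the first direct reading at this place: phenoxy can give way to benzyl, losing its oxygen and its hydrogen-bond acceptor, without a step beyond the scatter. Nothing available here explains why the two groups read alike.

The compounds shown leave open whether a cyclohexyl ring, a morpholine or a carboxylic acid in this place would keep the number in the same range. They also leave open how a longer chain between the amine nitrogen and the benzene ring would read in this assay.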